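Inverting the pyrrolidine stereocentre on the shared core

The source may hold more compounds than are shown below. What is called first, only, known or untested is meant among the compounds shown, and "the series" means these compounds.

Measured compounds:
Compound 1, `Cn1cc(-c2n[nH]c3ccc(Br)cc23)cn1`: 1540 nM
Compound 2, `Cn1cc(-c2n[nH]c3ccc(N[C@H]4CCNC4)cc23)cn1`: 239000 nM

In an assay on isolated protein for inhibition of tyrosine-protein kinase receptor UFO (Homo sapiens), with a stated time of 1.5 h (on this read-out higher numbers stand for weaker inhibition and lower numbers for stronger inhibition), compound 1 gives 1540 nM, while compound 2 gives 239000 nM. Compound 2 therefore stands at the higher of the two numbers, its nearest neighbour being compound 1 at a step of a 160-fold higher number from compound 1 to compound 2 (2.19 log units; beyond the scatter). That step came with the exchange of (pyrrolidin-3-yl)amino for bromo on an aromatic carbon.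

Compound 3, `Cn1cc(-c2n[nH]c3ccc(N[C@@H]4CCNC4)cc23)cn1`, differs from compound 2 as follows: the two compounds have the same atoms and bonds and differ only in configuration as drawn: 1 of 1 stereo elements differ; a stereocentre at a saturated ring carbon is drawn S in compound 2 and R in compound 3. Among the compounds with values here, no measured step bears on a change of configuration; the only measured step, from compound 1 to compound 2, concerns a different change and says nothing about the drawn stereocentre. Within the data shown here, compound 3 thus shares every atom and bond with compound 2, and the data give no direction for the step. Because compound 2 sits at 239000 nM, compound 3 is expected to fall below that number by a step of about a 4.0-fold lower number from compound 2 to compound 3 (0.60 log units; beyond the scatter), with wide uncertainty. The estimate for compound 3 in this assay is 60000 nM, within the range 5000 nM to 500000 nM.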

Compound 3, half-maximal inhibitory concentration: 37000 nM
The estimate for compound 3 lay 1.6-fold (0.21 log units) above the measured number, and the stated range covers the measured number.
By their numbers in this assay, from the lowest: compound 1; then compound 3; then compound 2.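

In this assay, within the data shown here, the configuration of the pyrrolidine stereocentre affects the read-out, something the earlier compounds could not show, since their only step exchanged bromo for the whole (pyrrolidin-3-yl)amino group. Moving from the S to the R drawing gives a 6.5-fold lower number from compound 2 to compound 3 (0.81 log units; beyond the scatter). This gap can be assigned to the stereocentre alone, because nothing else separates the pair: the fact that compounds 2 and 3 differ only in the configuration as drawn

The R drawing narrows the loss that came with replacing bromo but does not remove it, leaving a 24-fold higher number from compound 1 to compound 3 (1.38 log units; beyond the scatter).

The compounds shown leave open whether a piperidine in place of the pyrrolidine, or an open-chain amine such as an aminoethylamino group, would lie closer to the bromo compound in this assay. They also leave open whether the gain from the R drawing would persist with a methyl group added to the pyrrolidine ring, since a single pair of mirror-image drawings on one core gives no wider rule for this position.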